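Methylsulfanyl series: cytotoxicity notes toward compound 4

The source may hold more compounds than are shown below. What is called first, only, known or untested is meant among the compounds shown, and "the series" means these compounds.

Measured so far in a functional assay on A549 cells (Homo sapiens) for cytotoxicity, read by MTT assay, with a stated time of 48 h; a higher number here means a weaker inhibitor, a lower number a stronger inhibitor:
- compound 1 `CSc1nnc(C)n1N1C(=O)c2ccccc2C1=O`: > 200000 nM, a limit of the assay.
- compound 2 `C#CCSc1nnc(CCC)n1N1C(=O)c2ccccc2C1=O`: > 200000 nM, a limit of the assay.
- compound 3 `CCCc1nnc(SCc2ccccc2Cl)n1N1C(=O)c2ccccc2C1=O`: > 200000 nM, a limit of the assay.

Compound 3 thus stands at the limit of > 200000 nM in this assay, at which 3 of the 3 values shown sit; no number separates it from the others. Among the measured compounds shown here, the one step between measured neighbours, a step that the two limits leave unreadable from compound 2 to compound 3, is unreadable. Compound 4 `CCCc1nnc(SC)n1N1C(=O)c2ccccc2C1=O` differs from compound 3 by hydrogen in place of 2-chlorophenyl on a saturated chain carbon bound to a sulfur. Compound 1, which also carries methylsulfanyl, gives only a limit in this assay. Hence compound 4 is expected to remain beyond the limit, estimated at 300000 nM within 150000 nM to 1000000 nM. The expected step that the limit leaves unreadable from compound 3 to compound 4 is therefore none beyond the scatter.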

Compound 4, half-maximal inhibitory concentration: > 200000 nM
Compound 4: no number, only a limit; the forecaster's own chance of this, stated with the estimate: 85%; the middle value is on the limit's open side.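

Among the compounds shown here, compound 1, compound 2, compound 3 and compound 4 all give only a limit, so no step among them can be read: the limit of > 200000 nM in this assay, at which 4 of the 4 values shown sit. The compounds shown leave open whether any change on the shared core would give a measurable value.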